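The compounds below may be only part of what the source reports. "The series", "measured", "known", "first", "only" and "open" are said of these compounds alone.

Measured in an ADME assay on Raji cells (Homo sapiens) for cytotoxicity, read by CellTiter-Glo and resazurin assay, with a stated time of 72 h; a higher number here means that more compound is needed for the effect, a lower number that less compound is needed:
compound 1 `CC(C)Oc1cccc(-c2ccc(C(=O)N(Cc3cccc(OCCCCCC(=O)O)c3)C(C)C)cc2)c1` – only a limit, > 26000 nM.
compound 2 `CC(C)N(Cc1cccc(OCCCCCC(=O)O)c1)C(=O)c1ccc(-c2cccc(Oc3ccccc3)c2)cc1` – only a limit, > 18700 nM.

Compound 2 stands at a limit of this assay, as does compound 1, so the step that the two limits leave unreadable from compound 1 to compound 2 cannot be read. Compound 3 `CC(C)N(Cc1cccc(OCCCCCC(=O)O)c1)C(=O)c1ccc(-c2cccc(OCc3ccccc3)c2)cc1` differs from compound 2 by benzyl in place of phenyl on an oxygen on an aromatic ring. For the measured compounds named here, no measured step bears on this change; both values shown are limits, the limit of > 18700 nM in this assay, at which 1 of the 2 values shown sits, and (the limit of > 26000 nM in this assay, at which 1 of the 2 values shown sits), so a further limit is the most likely outcome and no direction can be set in this assay. Compound 3 is expected to give 30000 nM, with an estimated range from 10000 nM to 100000 nM. The step this estimate implies is a step that the limit leaves unreadable from compound 2 to compound 3.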

Compound 3, half-maximal effective concentration: > 26000 nM
Compound 3: no number, only a limit; the forecaster's own chance of this, stated with the estimate: 85%; the middle value does not contradict the limit.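

In this assay compound 3 gives only a limit of > 26000 nM and, with compound 1 and compound 2 also at limits, no step among these compounds can be read. The compounds shown leave open at what concentration any of them reaches the half-maximal effect, and whether isopropyl, phenyl or benzyl on the oxygen makes any difference to it.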